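The source may report more compounds than this note shows. Statements on the series, on what has been measured and on what is new or still open speak of the compounds shown alone.

The measured compounds:

Compound 1, `N#C/C(=C\c1ccc(Cl)cc1)C(=O)c1ccc[nH]1`, in a functional assay on SJ-G2 cells (Homo sapiens) for inhibition, read by MTT assay, with a stated time of 72 h (on this read-out higher numbers stand for weaker inhibition of growth and lower numbers for stronger inhibition of growth), gives 37000 nM.
Compound 2, `N#C/C(=C\c1ccc([N+](=O)[O-])cc1)C(=O)c1c[nH]c2ccccc12`, gives 37000 nM.
Compound 3, `N#C/C(=C\c1ccc[nH]1)C(=O)NCc1ccc(Cl)c(Cl)c1`, gives only > 50000 nM, which is a limit of the assay and not a number.

Compound 1 and compound 2 lie within the usual scatter of each other, so nothing separates them. Among the compounds with values here, compound 3 is the one value that is only a limit: the limit of > 50000 nM in this assay, at which 1 of the 3 values shown sits, places it at the edge of what the assay reports, so where it truly stands relative to compound 1 and compound 2 cannot be read from the numbers. Within the data shown here, the three measured compounds differ from one another in several places at once, so no single step between them is available.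

Compound 4, `N#C/C(=C\c1ccco1)C(=O)NCc1ccc(Cl)c(Cl)c1`, has not been measured. The change from compound 3 is furan-2-yl in place of 1H-pyrrol-2-yl on a double-bonded chain carbon bound to a double-bonded chain carbon. Among the measured compounds shown here, no measured pair isolates this change, and the starting point is itself a limit, so there is no basis to expect a step beyond the scatter in either direction. The value expected for compound 4 is 50000 nM, within a range from 20000 nM to 120000 nM. The change this estimate implies, a number no higher from compound 3 to compound 4 (the limit leaves the size open), is expected to stay within the scatter, and a further limit rather than a number is thought likely.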

Compound 4, concentration for 50% growth inhibition: > 50000 nM
Compound 4 ended at the assay's limit; the forecaster's own chance of this, stated with the estimate: 60%; the middle value sits exactly at the limit.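

In this assay compound 4 gives > 50000 nM as a limit of the assay and not a number. Compound 3 also stands at a limit, so no step can be read from compound 3 to compound 4: the limit of > 50000 nM in this assay, at which 2 of the 4 values shown sit. The compounds shown leave open whether furan-2-yl in place of 1H-pyrrol-2-yl shifts growth inhibition at all.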